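A few compounds are considered here, and "the series" means these few. Any claim that something is new, unique, unknown or untested is made for them only; others in the source may bear on it.

In a functional assay on the whole organism for agonist activity, with Mus musculus as the target (on this read-out lower numbers stand for an effect already at smaller amounts and higher numbers for an effect only at larger amounts of compound), compound 1 (`CC(=O)N(C)CC#CCn1ccnc1`) gives 1.4 mg/kg and compound 2 (`COC(=O)N(C)CC#CCN1CCCC1`) gives 5.5 mg/kg. Compound 2 therefore has the higher of the two numbers, and the gap to compound 1 lies beyond the usual scatter. A higher dose is thus needed for the half-maximal effect with compound 2.

Compound 3 (`COC(=O)N(C)CC#CCn1ccnc1`) keeps most of compound 2 but replaces one group, with 1H-imidazol-1-yl in place of pyrrolidin-1-yl on a saturated chain carbon bound to a triple-bonded carbon.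

For the measured compounds named here, no pair of measured compounds shows this swap on its own, so the evidence is thin. Although it differs from compound 3 elsewhere, compound 1 also carries the 1H-imidazol-1-yl group, and compound 1 at 1.4 mg/kg is the only hint available. That hint leans towards a lower number than that of compound 2.

The expected change, a 2.2-fold lower number from compound 2 to compound 3 (0.34 log units; beyond the scatter), is a moderate move in that direction, and this size is only an estimate. For compound 3, the estimated value in this assay is 2.5 mg/kg, with an expected range from 0.7 mg/kg to 10 mg/kg.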

Compound 3, dose for half-maximal effect: 4.5 mg/kg
Estimate against measurement, compound 3: 1.8-fold (0.26 log units) below, and the stated range covers the measured number.
By their numbers in this assay, from the lowest: compound 1; then compounds 3 and 2 (each within the scatter of the next).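

Exchanging pyrrolidin-1-yl for 1H-imidazol-1-yl on a saturated chain carbon bound to a triple-bonded carbon replaces a non-aromatic ring with an aromatic one, yet in this assay it gives a 1.2-fold lower number from compound 2 to compound 3 (0.09 log units; within the scatter), so this change leaves no clear mark on the dose needed. The other single change now stands out: with 1H-imidazol-1-yl kept in place, methoxy in place of methyl on a carbonyl carbon gives a 3.2-fold higher number from compound 1 to compound 3 (0.51 log units; beyond the scatter), a modest but real step in this series. No accompanying measurement speaks to what lies behind either step. Going by these compounds, whether methyl on the carbonyl carbon would also give a lower number than methoxy with pyrrolidin-1-yl in place remains open, since the comparison rests on a single pair of compounds. Also open, on these data alone, is how a piperidin-1-yl ring or an open-chain dimethylamino group on that same carbon, or an ethyl group on the carbonyl carbon, would read in this assay, and whether the ring swap would stay as quiet with those neighbouring choices.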